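The source may report more compounds than this note shows. Statements on the series, on what has been measured and on what is new or still open speak of the compounds shown alone.

In a functional assay on MV4-11 cells (Homo sapiens) for inhibition, with a stated time of 72 h (a lower number here means a stronger inhibitor, a higher number a weaker inhibitor), compound 1 `CC(C)N(Cc1ccc(C(=O)NO)cc1)S(=O)(=O)c1c(F)c(F)c(F)c(F)c1F` gives 510 nM, compound 2 `CC(C)CN(Cc1ccc(C(=O)NO)cc1)S(=O)(=O)c1cc(F)c(F)c(F)c1F` gives 520 nM and compound 3 `COCCN(Cc1ccc(C(=O)NO)cc1)S(=O)(=O)c1cc(F)c(F)c(F)c1F` gives 660 nM. Compound 3 thus stands within the scatter of both others. Compound 4 `CC(C)N(Cc1ccc(C(=O)NO)cc1)S(=O)(=O)c1cc(F)c(F)c(F)c1F` differs from compound 3 on one substituent: isopropyl in place of 2-methoxyethyl on a sulfonamide nitrogen. Within the data shown here, the one measured step at this nitrogen substituent, a 1.3-fold higher number from compound 2 to compound 3 (0.10 log units; within the scatter), lies within the scatter. Compound 1 also carries isopropyl on a sulfonamide nitrogen, and its 510 nM gives no sign of a larger shift. No change beyond the scatter is therefore expected in this assay, and no direction is favoured. The expected step is a 1.3-fold lower number from compound 3 to compound 4 (0.10 log units; within the scatter). For compound 4 the estimated value is 520 nM, with an expected range of 280 nM to 950 nM.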

Compound 4, half-maximal inhibitory concentration: 1190 nM
The estimate for compound 4 lay 2.3-fold (0.36 log units) below the measured number, outside the stated range (above it).
By their numbers in this assay, from the lowest: compounds 1, 2, 3 and 4 (each within the scatter of the next, the first and the last beyond it).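

At the sulfonamide nitrogen, isopropyl in place of isobutyl gives a modest step beyond the scatter in this assay (a 2.3-fold higher number from compound 2 to compound 4 (0.36 log units; beyond the scatter)), whereas isopropyl in place of 2-methoxyethyl stays within it (a 1.8-fold higher number from compound 3 to compound 4 (0.26 log units; within the scatter)). Hydrogen in place of fluoro on an aromatic carbon, the first change read away from that nitrogen, is also modest and beyond the scatter (a 2.3-fold higher number from compound 1 to compound 4 (0.37 log units; beyond the scatter)). No measured evidence explains these steps. As far as these compounds go, whether an amine or a longer chain on the sulfonamide nitrogen would keep the number near that of compound 2 remains open, as does the effect of chloro on the aromatic carbon.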